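This account rests on a few compounds, and the source may have more. Where it says the series, first, only, none or still open, it means among the compounds named here.

Going by the values given here, compound 3 `O=c1c2ccccc2[se]n1-c1nc(SCc2ccc(F)cc2)n[nH]1` is one of three compounds measured in an ADME assay on L929 cells (Mus musculus) for antiproliferative activity, read by CCK-8 assay, with a stated time of 48 h; on this read-out higher numbers stand for weaker inhibition and lower numbers for stronger inhibition. Compound 1 `CC(C)CSc1n[nH]c(-n2[se]c3ccccc3c2=O)n1` gives 33400 nM, and compound 2 `O=c1c2ccccc2[se]n1-c1nc(SCc2ccc(Cl)cc2)n[nH]1` gives 39500 nM. For compound 3 the assay reports only a limit, > 50000 nM. That is the limit of > 50000 nM in this assay, at which 1 of the 3 values shown sits, so compound 3 stands at the upper edge of the numbers shown, without a number of its own. The change leading to compound 4 `CCCSc1n[nH]c(-n2[se]c3ccccc3c2=O)n1` is ethyl in place of 4-fluorophenyl on a saturated chain carbon bound to a sulfur. The measured steps that bear on it run through the same position: an at least 1.4-fold higher number from compound 1 to compound 3 (0.17 log units; that floor lies within the scatter) and a 1.2-fold higher number from compound 1 to compound 2 (0.07 log units; within the scatter), together with the exchange of halogens, an at least 1.2-fold higher number from compound 2 to compound 3 (0.10 log units; that floor lies within the scatter). Every one of them stayed within the scatter, so the return from an aromatic group to a short chain is expected to give no step beyond the scatter in this assay, with at most a small move toward the number of compound 1, which sits at 33400 nM. The expected step is an at least 1.4-fold lower number from compound 3 to compound 4 (0.15 log units; that floor lies within the scatter). Compound 4 is therefore estimated at 35000 nM, within a range from 15000 nM to 80000 nM.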

Compound 4, half-maximal inhibitory concentration: 31800 nM
Compound 4: middle estimate off by 1.1-fold (0.04 log units), on the high side, within the range that was stated.
By their numbers in this assay, from the lowest: compounds 4, 1 and 2 (each within the scatter of the next). At a limit, above all of these: compound 3.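

With compound 4, this position carries an unbranched chain as well as a branched one, and in this assay hydrogen in place of methyl on a saturated chain carbon bound to two saturated chain carbons gives a 1.1-fold lower number from compound 1 to compound 4 (0.02 log units; within the scatter). Ethyl in place of 4-chlorophenyl gives a 1.2-fold lower number from compound 2 to compound 4 (0.09 log units; within the scatter), so among the compounds with a number of their own, exchanging an aromatic group for a short chain here leaves the read-out within the scatter. Ethyl in place of 4-fluorophenyl gives an at least 1.5-fold lower number from compound 3 to compound 4 (0.19 log units; that floor lies within the scatter), but compound 3 has only a limit, so this step is a floor and its true size cannot be read: the limit of > 50000 nM in this assay, at which 1 of the 4 values shown sits.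

As far as these compounds go, whether an amine, a carboxylic acid or a much longer chain at this position would give a step beyond the scatter remains open. So does any effect of changing the shared core, which all of these compounds keep.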